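Triazole aryl swap carried from one core to another

This account rests on a few compounds, and the source may have more. Where it says the series, first, only, none or still open, it means among the compounds named here.

Compound 1 `CC(C)=CCC/C(C)=C/CC/C(C)=C/CC[C@@H]1[C@@]2(C)CC/C(=N\OCc3cn(-c4ccc(Cl)cc4)nn3)C(C)(C)[C@@H]2CC[C@@]1(C)O` carries a 1-(4-chlorophenyl)-1H-1,2,3-triazol-4-yl group on its core; in a functional assay on MCF7 cells (Homo sapiens) for cytotoxicity, read by MTT assay, with a stated time of 48 h (on this read-out higher numbers stand for weaker inhibition and lower numbers for stronger inhibition), compound 1 gives 12400 nM. Compound 2 `CC(C)=CCC/C(C)=C/CC/C(C)=C/CC[C@@H]1[C@@]2(C)CC/C(=N\OCc3cn(-c4cccc(Br)c4)nn3)C(C)(C)[C@@H]2CC[C@@]1(C)O` differs from it by 3-bromophenyl in place of 4-chlorophenyl on an aromatic nitrogen and in this assay compound 2 gives 24800 nM. The measured step is a 2.0-fold higher number from compound 1 to compound 2 (0.30 log units; within the scatter), so on this pair the swap leaves the read-out essentially unchanged.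

Compound 3 `CC(C)=CCC/C(C)=C/CC/C(C)=C/CC[C@@H]1[C@@]2(C)C/C(=C\c3ccc(OCc4cn(-c5ccc(Cl)cc5)nn4)cc3)C(=O)C(C)(C)[C@@H]2CC[C@@]1(C)O` carries the same 1-(4-chlorophenyl)-1H-1,2,3-triazol-4-yl group on a different core; the difference between the core of compound 1 and the core of compound 3 is not broken down here. In this assay compound 3 gives 72400 nM, the highest number of the three measured compounds, beyond the scatter from both compound 1 and compound 2.

Compound 4 `CC(C)=CCC/C(C)=C/CC/C(C)=C/CC[C@@H]1[C@@]2(C)C/C(=C\c3ccc(OCc4cn(-c5cccc(Br)c5)nn4)cc3)C(=O)C(C)(C)[C@@H]2CC[C@@]1(C)O` is derived from compound 3 by 3-bromophenyl in place of 4-chlorophenyl on an aromatic nitrogen, the same change as that from compound 1 to compound 2 at the same kind of place. For the measured compounds named here, only one measured instance of this change exists, so the expectation for compound 4 rests on a 2.0-fold higher number from compound 1 to compound 2 (0.30 log units; within the scatter) alone, giving an expected step of a 1.8-fold higher number from compound 3 to compound 4 (0.25 log units; within the scatter). Compound 3 already gives 72400 nM, the highest number of the three measured compounds, and compound 4 is expected to lie higher still. Compound 4 is expected to give 130000 nM, with a plausible range from 55000 nM to 300000 nM.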

Compound 4, half-maximal inhibitory concentration: 61000 nM
Beside the measured number, compound 4's estimate is 2.1-fold (0.33 log units) above it; measured number inside the range.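

In this assay, 3-bromophenyl in place of 4-chlorophenyl on an aromatic nitrogen gives a 1.2-fold lower number from compound 3 to compound 4 (0.07 log units; within the scatter), so on this second core the swap again leaves the read-out essentially unchanged. The change therefore carries from one core to the other without a difference that can be told apart on this read-out: the same change on two cores in this assay, a 2.0-fold higher number (0.30 log units; within the scatter) from compound 1 to compound 2 and a 1.2-fold lower number (0.07 log units; within the scatter) from compound 3 to compound 4, 2.4-fold (0.38 log units) apart, within the scatter of two such steps. For the compounds shown here, this rests on only two pairs, both with steps inside the scatter, so it does not show that the two aryl groups are interchangeable on any further core, and it cannot separate the halogen from its place on the phenyl ring, as both change together in each pair.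

Still open, going by these compounds, is how 4-bromophenyl or 3-chlorophenyl would read on either core, which would pull the halogen and its place apart. Also open, on these data alone, is whether a group of another kind in place of the 4-chlorophenyl, such as unsubstituted phenyl, benzyl or a phenyl bearing an amine or a carboxylic acid, would move the number beyond the scatter, and whether such a change would then carry between the two cores as this one does.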